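The expected swap on the carbonyl carbon

A few compounds are considered here, and "the series" means these few. Any claim that something is new, unique, unknown or untested is made for them only; others in the source may bear on it.

Measured so far in an ADME assay on a cell-free system (plasma, Homo sapiens) for metabolic stability, read by HPLC (a higher number here means that the compound lasts longer, a lower number that the compound disappears faster), are two compounds:
compound 1 `CCOC(=O)c1ccc(/N=N/N(C)C(=O)CCCCc2ccc(O)cc2)cc1` with 26.3 h
compound 2 `CC(=O)c1ccc(/N=N/N(C)C(=O)CCCCc2ccc(O)cc2)cc1` with 32.7 h

Among the measured compounds shown here, compound 1 stands level with compound 2, the only other measured compound, as their two numbers lie within the usual scatter of each other. Compound 3 `CN(/N=N/c1ccc(C(N)=O)cc1)C(=O)CCCCc1ccc(O)cc1` has not yet been measured. Its change from compound 1 reads amino in place of ethoxy on a carbonyl carbon in full. For the measured compounds named here, one measured step bears on it: methyl in place of ethoxy on that same carbonyl carbon gives a 1.2-fold higher number from compound 1 to compound 2 (0.09 log units; within the scatter) as its size. From the compounds shown here alone, on the strength of that single step, no change beyond the scatter in either direction is expected in this assay for this swap, though amino itself is untested here. The estimated step is a 1.1-fold higher number from compound 1 to compound 3 (0.04 log units; within the scatter) and nothing larger is expected. The estimate for compound 3 is 29 h with an expected range from 14 h to 60 h in all.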

Compound 3, half-life: 55.4 h
Compound 3: middle estimate off by 1.9-fold (0.28 log units), on the low side, within the range that was stated.
By their numbers in this assay, from the lowest: compounds 1, 2 and 3 (each within the scatter of the next, the first and the last beyond it).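

In this assay, among the compounds shown here, this carbonyl carbon shows for the first time a swap that leaves the scatter: amino in place of ethoxy gives a 2.1-fold higher number from compound 1 to compound 3 (0.32 log units; beyond the scatter), whereas the methyl swap had stayed within it. Amino in place of methyl on the same carbon gives a 1.7-fold higher number from compound 2 to compound 3 (0.23 log units; within the scatter), so the methyl and amino compounds cannot be told apart here, and only the ethoxy and amino pair is separated. Nothing available accounts for that separation. The compounds shown leave open how other groups on this carbonyl carbon would read, such as methylamino, dimethylamino or the hydroxyl of a carboxylic acid. For the compounds shown here, they also leave open whether the step from ethoxy to amino would hold on a core other than the one these three compounds share.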